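The compounds below may be only part of what the source reports. "The series", "measured", "known", "first", "only" and "open" are said of these compounds alone.

In an assay on isolated protein for inhibition of acid ceramidase (Homo sapiens), read by LC-MS, with a stated time of 1 h (a higher number here means a weaker inhibitor, a lower number a stronger inhibitor), compound 1 `CCCCCNC(=O)n1c(-c2ccccc2)coc1=O` gives 25 nM, compound 2 `CCOCCNC(=O)n1cc(-c2ccccc2)oc1=O` gives 2040 nM, and compound 3 `COc1ccc(-c2cn(C(=O)NCCCCc3ccccc3)c(=O)o2)cc1` gives 400 nM. Among these three numbers compound 3 stands second highest: its value lies above that of compound 1 and below that of compound 2, and both of those gaps are beyond the usual scatter of this assay.

Compound 4 `O=C(NCCCCc1ccccc1)n1cc(-c2nccs2)oc1=O` has not yet been measured. It differs from compound 3 in one place: 1,3-thiazol-2-yl in place of 4-methoxyphenyl on an aromatic carbon. The carbamate chain with its phenyl end and the shared core stay the same. Within the data shown here, no measured pair in this set shows the effect of swapping the aromatic group on this carbon, so the size of the step can only be guessed.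

The step from compound 3 to compound 4 in this assay is expected to be small, a 1.6-fold higher number from compound 3 to compound 4 (0.21 log units; within the scatter), most likely a mild weakening that may not exceed the scatter. Compound 4 is therefore estimated at 650 nM, with a plausible range from 200 nM to 2200 nM.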

Compound 4, half-maximal inhibitory concentration: 59 nM
Compound 4: the middle estimate sits 11-fold (1.04 log units) above what was measured, and the stated range ends above it.
By their numbers in this assay, from the lowest: compound 1; then compound 4; then compound 3; then compound 2.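

In this assay with the chain and its phenyl end held fixed, putting 1,3-thiazol-2-yl in place of 4-methoxyphenyl on this aromatic carbon, next to the ring oxygen, gives a 6.8-fold lower number from compound 3 to compound 4 (0.83 log units; beyond the scatter) and so a stronger inhibitor. Among these compounds, this is the first direct look at this position, and it shows that the group here affects the read-out by more than the scatter. It also shows that a six-membered aromatic ring of carbon only is not required here, as a five-membered aromatic ring with 2 hetero atoms serves better in this pair, though nothing available explains the gain.

Still open, going by these compounds, is whether an unsubstituted phenyl, a pyridine ring or a thiophene ring on this carbon would match 1,3-thiazol-2-yl. Also open, on these data alone, is whether the same swap would hold with a shorter chain, such as butyl.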